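Swapping the Aryl Group on Compound 3

A few compounds are considered here, and "the series" means these few. Any claim that something is new, unique, unknown or untested is made for them only; others in the source may bear on it.

Measured in a functional assay on HepG2 cells (Homo sapiens) for antiproliferative activity, read by spectrophotometry, with a stated time of 2 days; a lower number here means a stronger inhibitor of growth, a higher number a weaker inhibitor of growth:
- compound 1 `CN(c1cccc2c1CN(c1nc(Nc3cc(C(F)(F)F)cc(C(F)(F)F)c3)ncc1C(F)(F)F)C2)S(C)(=O)=O`: 10300 nM
- compound 2 `COc1cc(Nc2ncc(C(F)(F)F)c(N3Cc4cccc(N(C)S(C)(=O)=O)c4C3)n2)cc(OC)c1`: 1800 nM
- compound 3 `Cc1cc(Cl)ccc1Nc1ncc(C(F)(F)F)c(N2Cc3cccc(N(C)S(C)(=O)=O)c3C2)n1`: 19600 nM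

Compound 3 gives 19600 nM, and compound 1 gives 10300 nM. These two values lie within the usual scatter of each other. Going by the values given here, compound 2 stands clearly apart, and the one measured step shows an 11-fold higher number from compound 2 to compound 3 (1.04 log units; beyond the scatter). That step is large and exchanges one aryl group for another on a nitrogen on an aromatic ring, so a swap at this nitrogen can move the number far.

The next compound is compound 4 `CN(c1cccc2c1CN(c1nc(Nc3cc(Cl)cc(C(F)(F)F)c3)ncc1C(F)(F)F)C2)S(C)(=O)=O`. It has 3-chloro-5-(trifluoromethyl)phenyl in place of 4-chloro-2-methylphenyl on a nitrogen on an aromatic ring. Among the compounds with values here, no measured step covers this exact swap. The nearest guide is compound 1 at 10300 nM, whose group on the same nitrogen also carries trifluoromethyl. Its value is within the scatter of the value of compound 3, so no step beyond the scatter is expected here. In this assay the expected step is a 1.8-fold lower number from compound 3 to compound 4 (0.25 log units; within the scatter). The large step seen earlier keeps the range wide. Compound 4 is estimated at 11000 nM, with an expected range from 4500 nM to 25000 nM.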

Compound 4, concentration for 50% growth inhibition: 9900 nM
Estimate against measurement, compound 4: 1.1-fold (0.05 log units) above, and the stated range covers the measured number.
By their numbers in this assay, from the lowest: compound 2; then compounds 4, 1 and 3 (each within the scatter of the next).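

In this assay, the new aryl group on this nitrogen gives a 2.0-fold lower number from compound 3 to compound 4 (0.30 log units; within the scatter), so two aryl groups with different substituents cannot be told apart here. Changing a single substituent on the aryl group, with chloro in place of trifluoromethyl on an aromatic carbon, gives a 1.0-fold lower number from compound 1 to compound 4 (0.02 log units; within the scatter), so this exchange also leaves no readable difference. With 3-chloro-5-(trifluoromethyl)phenyl in place of 3,5-dimethoxyphenyl, the step is a 5.5-fold higher number from compound 2 to compound 4 (0.74 log units; beyond the scatter), which is modest but beyond the scatter, so compound 2 stands apart from compound 4 as well as from compound 3. No measurement shown here explains why the 3,5-dimethoxyphenyl compound differs from these two.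

The compounds shown leave open whether both methoxy groups are needed for the lower number of compound 2, which a phenyl group carrying one methoxy group, or one methoxy group with one chloro, could help to test. They also leave open how a pyridine ring or a cyclohexyl group would compare with these phenyl groups on the same nitrogen.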